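Extending the Hydroxamate Chain on Two Related Cores

A few compounds are considered here, and "the series" means these few. Any claim that something is new, unique, unknown or untested is made for them only; others in the source may bear on it.

Compound 1 `Nc1ncnc2c1c(-c1cnc3[nH]ccc3c1)nn2CCCCCCCCCC(=O)NO` gives 23500 nM in a functional assay on SK-HEP1 cells (Homo sapiens) for inhibition, read by MTT assay, with a stated time of 72 h; a higher number here means a weaker inhibitor, a lower number a stronger inhibitor.
Compound 2 `Nc1ncnc2c1c(-c1cnc3[nH]ccc3c1)nn2CCCCCCC(=O)NO` gives 14700 nM in this assay.
Compound 3 `Nc1nc2cc(-c3nn(CCCCCC(=O)NO)c4ncnc(N)c34)ccc2o1` gives 3080 nM in this assay.

Compounds 1 and 2 share one core, while compound 3 is built on another; the difference between the two cores is not broken down here. Within the first pair, the change is 3-(hydroxycarbamoyl)propyl in place of hydroxycarbamoyl on a saturated chain carbon, six bonds along the chain from an aromatic nitrogen, and the step it made was a 1.6-fold higher number from compound 2 to compound 1 (0.20 log units; within the scatter). Compound 3 stands lowest of the three measured numbers, and its gap to each of the other two lies beyond the scatter.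

Compound 4 `Nc1nc2cc(-c3nn(CCCCCCCCC(=O)NO)c4ncnc(N)c34)ccc2o1` has not yet been measured. It differs from compound 3 by 3-(hydroxycarbamoyl)propyl in place of hydroxycarbamoyl on a saturated chain carbon, five bonds along the chain from an aromatic nitrogen. Going by the values given here, this is the same kind of change as the one from compound 2 to compound 1, though not the same: there the place is six bonds along the chain from an aromatic nitrogen, here it is five. Compound 4 is therefore expected to show a step of a 1.6-fold higher number from compound 3 to compound 4 (0.20 log units; within the scatter) in this assay, resting on the earlier step of a 1.6-fold higher number from compound 2 to compound 1 (0.20 log units; within the scatter). Compound 4 is thus estimated at 4900 nM, most likely between 2000 nM and 12000 nM.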

Compound 4, half-maximal inhibitory concentration: > 100000 nM
Compound 4: a limit, no number (the forecaster's own chance of this, stated with the estimate: 3%); at least 20-fold (1.30 log units) between middle value and limit.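

In this assay compound 4 gives > 100000 nM, which is a limit of the assay and not a number: the limit of > 100000 nM in this assay, at which 1 of the 4 values shown sits.

Putting 3-(hydroxycarbamoyl)propyl in place of hydroxycarbamoyl gives an at least 32-fold higher number from compound 3 to compound 4 (1.51 log units; beyond the scatter), so the same change did not carry over from one core to the other with the same size: the same change on two cores in this assay, a 1.6-fold higher number (0.20 log units; within the scatter) from compound 2 to compound 1 and an at least 32-fold higher number (1.51 log units; beyond the scatter) from compound 3 to compound 4, at least 20-fold (1.30 log units) apart, beyond the scatter of two such steps

The step on the core of compound 1 is therefore a poor guide to the step on the core of compound 3, at least for this one pair on each core. The limit leaves the true size of the step on the core of compound 3 unknown, and these data do not show why the two cores part ways.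

From the compounds shown here alone, it remains open how a chain of intermediate length would behave on the core of compound 3, and so whether the number climbs gradually or abruptly as the chain grows. Also open, going by these compounds, is whether a carboxylic acid in place of hydroxycarbamoyl would respond differently on the two cores.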